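The source may hold more compounds than are shown below. What is called first, only, known or untested is meant among the compounds shown, and "the series" means these compounds.

Measured compounds:
Compound 1, `Fc1ccc(-c2csc(N/N=C/c3ccc(-n4ccnc4)cc3)n2)cc1`, 18.7%
Compound 2, `Clc1ccc(-c2csc(N/N=C/c3ccc(-n4ccnc4)cc3)n2)c(Cl)c1`, 28.8%

In an ADME assay on THP-1 cells (Homo sapiens) for cytotoxicity, read by MTT assay, tested at 50 ug/mL (on this read-out lower numbers stand for less inhibition and higher numbers for more inhibition at the one concentration tested (going by the name of the read-out)), compound 2 stands highest of the two numbers, and its nearest neighbour is compound 1, the change being a number 10.1 percentage points higher from compound 1 to compound 2 (beyond the scatter). Compound 3, `Cc1ccc(-c2csc(N/N=C/c3ccc(-n4ccnc4)cc3)n2)cc1`, has not yet been measured in this assay. It differs from compound 2 in one place: 4-methylphenyl in place of 2,4-dichlorophenyl on an aromatic carbon. Going by the values given here, only one measured step bears on this change, the one from compound 1 to compound 2, in which the exchange of the 4-fluorophenyl for the 2,4-dichlorophenyl gave a number 10.1 percentage points higher from compound 1 to compound 2 (beyond the scatter). Among the compounds with values here, the change to compound 3 again removes the 2,4-dichlorophenyl, this time for a 4-methylphenyl, for which no measured analogue exists. The other compound with a single substituent on that ring is compound 1, and because compound 1 gives 18.7%, a modest step downward is expected, so the step is estimated as a number 7.8 percentage points lower from compound 2 to compound 3 (within the scatter). Compound 3 is therefore expected to give about 21% in this assay, within a range from 10% to 33%.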

Compound 3, a percentage reported as inhibition, at one concentration (the size of the read-out at that concentration, not a potency): 36%
The estimate for compound 3 lay 15 percentage points below the measured number; measured number outside the range, above it.
By their numbers in this assay, from the lowest: compound 1; then compounds 2 and 3 (each within the scatter of the next).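

In this assay, 4-methylphenyl in place of 2,4-dichlorophenyl, on the aromatic carbon next to the ring nitrogen, gave a number 7.2 percentage points higher from compound 2 to compound 3 (within the scatter) and so does not separate these two groups at this position. Methyl in place of fluoro on the same ring gave a number 17.3 percentage points higher from compound 1 to compound 3 (beyond the scatter) and, together with a number 10.1 percentage points higher from compound 1 to compound 2 (beyond the scatter) from the earlier step, this leaves the 4-fluorophenyl of compound 1 as the only one of the three groups set apart, at the low end of the read-out, while the higher level turns out not to need chlorine on the ring. Nothing shown here accounts for the difference between the fluoro and methyl compounds.

The compounds shown leave open whether this separation holds for other groups on that ring, such as methoxy, an amine or a carboxylic acid, and whether a phenyl ring with no substituent would stand with compound 1 or with compound 2 and compound 3. They also leave open what a single chlorine would give at this position, and whether the numbers follow the same order at any other concentration.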